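This account rests on a few compounds, and the source may have more. Where it says the series, first, only, none or still open, it means among the compounds named here.

Among the measured compounds shown here, compound 1 `CC1(C)C=C(n2ccccc2=O)c2cc(C(=O)c3ccco3)ccc2O1` gives 5.92 in a functional assay (trachea) with Rattus norvegicus as the target (a lower number here means a less potent compound, a higher number a more potent compound, by a factor of ten per unit of this negative logarithm), the second highest of the three numbers so far. Compound 2 `CC1(C)C=C(n2ccccc2=O)c2cc(C(=O)c3ccc([N+](=O)[O-])cc3)ccc2O1` lies nearest at 6.09, within the scatter, and compound 3 `CC1(C)C=C(n2ccccc2=O)c2cc(OC(=O)Nc3ccccc3F)ccc2O1` furthest at 4.22, well beyond it. For the measured compounds named here, the only single-point step measured is a number 0.17 log units higher from compound 1 to compound 2 (within the scatter), a swap of one aryl for another on the carbonyl carbon. Compound 4 `CC1(C)C=C(n2ccccc2=O)c2cc(C(F)(F)F)ccc2O1` differs from compound 1 by trifluoromethyl in place of (furan-2-yl)carbonyl on an aromatic carbon. Going by the values given here, no measured pair removes the carbonyl itself, so that step gives little guidance; the values of compound 1 and compound 3 show only how far a different link can move the number. For compound 4 the estimate is 5.3, within 4.4 to 6.2. The expected step is a number 0.62 log units lower from compound 1 to compound 4 (beyond the scatter), leaning lower with wide uncertainty.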

Compound 4, logarithm of the reciprocal of the active concentration, log(1/C): 7.37
For compound 4 the middle estimate is 2.07 log units below the measured one, and the stated range ends below it.
By their numbers in this assay, from the lowest: compound 3; then compounds 1 and 2 (each within the scatter of the next); then compound 4.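

In this assay this aromatic carbon does not need a carbonyl or a second aromatic ring for a high number: the step is a number 1.45 log units higher from compound 1 to compound 4 (beyond the scatter) with trifluoromethyl in place of (furan-2-yl)carbonyl. Exchanging one aryl for another on the carbonyl gave only a number 0.17 log units higher from compound 1 to compound 2 (within the scatter) and did not show this range. No evidence bears on the reason for the rise.

The compounds shown do not separate the contribution of trifluoromethyl from the loss of the (furan-2-yl)carbonyl. A nitrile or methyl at this carbon would help to tell these apart.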